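Hydroxy in Place of Nitro: What to Expect

The source may hold more compounds than are shown below. What is called first, only, known or untested is meant among the compounds shown, and "the series" means these compounds.

Of the compounds shown here, three sharing one core have been tested in a functional assay on K562 cells (Homo sapiens) for antiproliferative activity; a lower number here means a stronger inhibitor, a higher number a weaker inhibitor. Compound 1 `Nc1n[nH]c(N)c1/N=N/c1cccc2c1CCCC2` gives 55000 nM, compound 2 `Nc1n[nH]c(N)c1/N=N/c1ccccc1[N+](=O)[O-]` gives 100000 nM, and compound 3 `Nc1n[nH]c(N)c1/N=N/c1cccc([N+](=O)[O-])c1` gives 79000 nM. Compound 2 stands within the usual scatter of both of the others, so these numbers cannot rank it against either one.

The next compound to be tested is compound 4 `Nc1n[nH]c(N)c1/N=N/c1ccccc1O`. It differs from compound 2 in a single place: hydroxy in place of nitro on an aromatic carbon, ortho to a group of 9 heavy atoms (hydroxy in place of nitro on an aromatic carbon). Among the measured compounds shown here, no measured pair shows this swap directly, so the expectation has to rest on how little the three known values spread. Compound 1 carries no nitro group at all, yet its 55000 nM remains within the scatter of compound 2 at 100000 nM. A small change in this assay is therefore expected, leaning slightly toward a lower number and not clearly beyond the scatter. The estimated step is a 1.7-fold lower number from compound 2 to compound 4 (0.22 log units; within the scatter). Compound 4 is estimated at 60000 nM, with an expected range from 25000 nM to 130000 nM.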

Compound 4, half-maximal inhibitory concentration: > 100000 nM
Compound 4 gave a limit, no number (the forecaster's own chance of this, stated with the estimate: 20%); middle value at least 1.6-fold (0.22 log units) from the limit.
By their numbers in this assay, from the lowest: compounds 1, 3 and 2 (each within the scatter of the next).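

In this assay compound 4 gives > 100000 nM, which is a limit of the assay and not a number. This is the only pair shown that carries hydroxy in place of nitro on an aromatic carbon, ortho to a group of 9 heavy atoms, and it gives a number no lower from compound 2 to compound 4 (the limit leaves the size open), so this swap at this place did not bring the number down, something the spread among the earlier compounds could not tell. How far the step reaches cannot be read, because the reading ends at a limit: the limit of > 100000 nM in this assay, at which 1 of the 4 values shown sits.

The compounds shown leave open whether another group at this place, such as an amine, a methoxy group or a carboxylic acid, would give a lower number, and whether hydroxy would act the same way where the nitro group sits in compound 3. They also leave the wider picture unsettled, since compound 1, compound 3 and compound 2 each stand within the scatter of the next, and so no group shown here has yet moved the number clearly in the stronger direction.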